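Adding a Second Chlorine on the Distant Phenyl Ring

This account rests on a few compounds, and the source may have more. Where it says the series, first, only, none or still open, it means among the compounds named here.

Compound 1, `Cc1nc(Nc2ccc(Cl)cc2)sc1C(=O)/C=C/c1ccccc1`: 24600 nM
Compound 2, `Cc1nc(Nc2ccc(Cl)c(Cl)c2)sc1C(=O)/C=C/c1ccccc1`: 7990 nM
Compound 3, `Cc1cccc(Nc2nc(C)c(C(=O)/C=C/c3ccccc3)s2)c1`: 11700 nM

Of the compounds shown here, three built on the same core have been tested in a functional assay on PC-3 cells (Homo sapiens) for cytotoxicity, read by MTT assay; on this read-out lower numbers stand for stronger inhibition and higher numbers for weaker inhibition. Compound 2 gives the lowest of the three numbers. Compound 3 is its nearest neighbour, with a 1.5-fold higher number from compound 2 to compound 3 (0.17 log units; within the scatter), so these two cannot be told apart. Compound 1 is furthest away: the step of a 3.1-fold lower number from compound 1 to compound 2 (0.49 log units; beyond the scatter) is modest but clear.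

Compound 4, `Cc1nc(Nc2ccc(Cl)c(Cl)c2)sc1C(=O)/C=C/c1ccc(Cl)cc1`, has not yet been measured. It differs from compound 2 by chloro in place of hydrogen on an aromatic carbon. This chlorine goes onto the phenyl ring at the far end of the unsaturated ketone arm, whereas the chlorines already present in compound 2 sit on the aniline ring. Going by the values given here, the only measured step of the same kind is a 3.1-fold lower number from compound 1 to compound 2 (0.49 log units; beyond the scatter), and it concerns the other ring, so it offers limited guidance. A small move toward lower numbers, or no change beyond the scatter, seems the most reasonable expectation in this assay .

Compound 4 is therefore estimated at 5500 nM, within a range of 2500 nM to 12000 nM. This estimate corresponds to an expected 1.5-fold lower number from compound 2 to compound 4 (0.16 log units; within the scatter).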

Compound 4, half-maximal inhibitory concentration: > 25000 nM
Compound 4 was reported as a limit (the forecaster's own chance of this, stated with the estimate: 5%); middle value at least 4.5-fold (0.65 log units) from the limit.
By their numbers in this assay, from the lowest: compounds 2 and 3 (each within the scatter of the next); then compound 1. At a limit, above all of these: compound 4.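

In this assay, going by these compounds alone, turning the phenyl of the unsaturated ketone arm into 4-chlorophenyl gives an at least 3.1-fold higher number from compound 2 to compound 4 (0.49 log units; beyond the scatter), so this ring does not tolerate a chlorine in the way the earlier compounds might have suggested. The same kind of change on the aniline ring went the opposite way, with a 3.1-fold lower number from compound 1 to compound 2 (0.49 log units; beyond the scatter), which means that in these two steps the direction depends on which ring receives the chlorine and a result from one ring cannot simply be carried over to the other. The value of compound 4 is a limit and not an exact number, so the new step gives only the smallest size the change can have: the limit of > 25000 nM in this assay, at which 1 of the 4 values shown sits.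

The compounds shown leave open whether this rise belongs to chlorine itself or to any group at this place on the ring, and a fluorine, a methyl group, a methoxy group or an amine there would help to separate those two readings. They also leave open how a chlorine elsewhere on this same ring would behave, since only the 4-chlorophenyl form appears here.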